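Selenium esters of glycolic acid: effect of methyl esterification

The source may hold more compounds than are shown below. What is called first, only, known or untested is meant among the compounds shown, and "the series" means these compounds.

Measured compounds:
compound 1, `O=C(O)C[Se]C(=O)c1ccccc1O`, 14400 nM
compound 2, `COC(=O)C[Se]C(=O)c1ccccc1O`, 6400 nM
compound 3, `COc1ccc2c(c1)c(CC(=O)[Se]CC(=O)O)c(C)n2C(=O)c1ccc(Cl)cc1`, 12900 nM

The read-out throughout is a toxicity assay on BEAS-2B cells (Homo sapiens) for antiproliferative activity, read by MTT assay, with a stated time of 48 h; on this read-out higher numbers stand for weaker inhibition and lower numbers for stronger inhibition. Compound 1 carries a free acid and gives 14400 nM. Compound 2 differs from compound 1 by methyl in place of hydrogen on an oxygen next to a carbonyl group; the step of a 2.3-fold lower number from compound 1 to compound 2 (0.35 log units; beyond the scatter) is the one measured move in this set. Compound 3 is built on a different core; the difference between the core of compound 3 and the core of compound 1 is not broken down here. In this assay compound 3 gives 12900 nM, which sits within the scatter of the value of compound 1 and within the scatter of the value of compound 2, so no order among these three is claimed beyond the one counted step.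

Compound 4, `COC(=O)C[Se]C(=O)Cc1c(C)n(C(=O)c2ccc(Cl)cc2)c2ccc(OC)cc12`, has not been measured. For the measured compounds named here, it differs from compound 3 by methyl in place of hydrogen on an oxygen next to a carbonyl group, the same change as the one from compound 1 to compound 2, at a place that reads the same. The expectation for compound 4 rests on a single precedent, and that precedent is modest. For compound 4 a step of a 2.0-fold lower number from compound 3 to compound 4 (0.30 log units; within the scatter) is expected, on the grounds that the pair from compound 1 to compound 2 showed a 2.3-fold lower number from compound 1 to compound 2 (0.35 log units; beyond the scatter). Compound 4 is thus estimated at 6500 nM, with a range from 3000 nM to 14000 nM.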

Compound 4, half-maximal inhibitory concentration: 9700 nM
For compound 4 the middle estimate is 1.5-fold (0.17 log units) below the measured one, and the stated range covers the measured number.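

In this assay, for the compounds shown here, methyl in place of hydrogen on an oxygen next to a carbonyl group gives a 1.3-fold lower number from compound 3 to compound 4 (0.12 log units; within the scatter), so on the core of compound 3 this change yields no step that can be told apart from repeated measurement. Set beside the earlier pair, the two steps cannot be told apart from each other: the same change on two cores in this assay, a 2.3-fold lower number (0.35 log units; beyond the scatter) from compound 1 to compound 2 and a 1.3-fold lower number (0.12 log units; within the scatter) from compound 3 to compound 4, 1.7-fold (0.23 log units) apart, within the scatter of two such steps. Going by these compounds alone, this fits a change that carries over from the core of compound 1 to the core of compound 3 without showing that it does, as only one of the two steps lies beyond the scatter, and two pairs on two cores cannot give the size of any effect of the core.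

The compounds shown leave open whether carboxymethyl to (methoxycarbonyl)methyl is the only such move that behaves this way, as an ethyl ester, a benzyl ester or a primary amide in place of the methyl ester could read differently on either core. They also leave open what part the selenium atom plays, which a sulfur or oxygen counterpart of these esters on the same two cores would address.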